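This account rests on a few compounds, and the source may have more. Where it says the series, first, only, none or still open, it means among the compounds named here.

Compound 1, `COCc1nc2nc(C)cc(Nc3ccc(C(F)(F)F)cc3)n2n1`, in an ADME assay on a cell-free system (plasma, Homo sapiens) for protein binding, gives 75.6%.
Compound 2, `CCc1nc2nc(C)cc(Nc3cccc(Cl)c3)n2n1`, gives 86.7%.
Compound 3, `Cc1cc(Nc2ccc(S(F)(F)(F)(F)F)cc2)n2nc(C3CC3)nc2n1`, gives 97.7%.

Among these three values compound 2 and compound 1 lie within the usual scatter of each other, so nothing can be said about which of the two is the more bound. Compound 3, by contrast, shows a clearly smaller unbound fraction than compound 2, a gap that lies beyond the scatter. Compound 2 thus sits together with compound 1 at the more weakly bound end of this small set, with compound 3 set apart from both.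

Compound 4, `Cc1cc(Nc2cccc(Cl)c2)n2nc(C(C)(F)F)nc2n1`, has not yet been measured. Its structure differs from compound 2 in one place: 1,1-difluoroethyl in place of ethyl on an aromatic carbon. Going by the values given here, no measured pair in this set shares such a change, so no directly comparable step is known. On what the three measured compounds show, compound 4 is expected to remain close to compound 2, with at most a small shift toward more binding, a step of a 1.3-fold lower unbound fraction from compound 2 to compound 4 (0.12 log units; within the scatter) that would stay within the scatter. On that basis the estimate for compound 4 in this assay is 90%, with a range from 82% to 95%.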

Compound 4, plasma protein binding in the plasma assay: 88.2%
Estimate against measurement, compound 4: 1.2-fold (0.07 log units) (unbound fraction) below; low and high end bracket the measured number.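

Going by these compounds alone, at this position, on an aromatic carbon of a five-membered aromatic ring with 3 nitrogen, the change to 1,1-difluoroethyl in place of ethyl gives the only one-place step in this set, and in the plasma assay it reads a 1.1-fold lower unbound fraction from compound 2 to compound 4 (0.05 log units; within the scatter), so the change does not separate the two compounds in their binding to plasma protein. In a physicochemical assay for lipophilicity, at pH 7.4 (a higher number here means a more lipophilic compound, a lower number a more polar compound), compound 2 gives 2.8 and compound 4 gives 3, a pair whose step, a number 0.20 log units higher from compound 2 to compound 4 (within the scatter), likewise leaves the two compounds unseparated, so that two added fluorine atoms on this chain leave both read-outs where the scatter cannot tell them apart. Nothing shown here offers an explanation for the size of either step.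

The compounds shown leave open how binding at this position responds to a group of another kind, such as an amine, a carboxylic acid or a longer chain such as propyl. They also leave open whether the same change from ethyl to 1,1-difluoroethyl would read alike with the trifluoromethyl-bearing aromatic ring of compound 1 in place of the chlorine-bearing one shared by compound 2 and compound 4.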